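A few compounds are considered here, and "the series" means these few. Any claim that something is new, unique, unknown or untested is made for them only; others in the source may bear on it.

Measured so far:
compound 1 `CC(C)(C)OC(=O)/C=C1/C(=O)Nc2ccccc21` — 2450 nM
compound 2 `COc1cccc2c1NC(=O)/C2=C/C(=O)OC(C)(C)C` — "not determined" (no result reported)

For the measured compounds named here, in a toxicity assay on L02 cells (Homo sapiens) for cytotoxicity, read by CCK-8 assay, with a stated time of 72 h (on this read-out lower numbers stand for stronger inhibition and higher numbers for weaker inhibition), compound 1 gives 2450 nM, the only number in this set, since compound 2 has no reported result. Compound 3 `CC(C)(C)OC(=O)/C=C1/C(=O)Nc2ccc(Cl)cc21` differs from compound 1 by chloro in place of hydrogen on an aromatic carbon. Going by the values given here, no pair of measured compounds shows what such a change does here, so the step from compound 1 to compound 3 is expected to be a 1.4-fold lower number from compound 1 to compound 3 (0.13 log units; within the scatter), a slight shift toward stronger inhibition that need not exceed the usual scatter. Compound 3 is therefore estimated at 1800 nM, with a range from 600 nM to 5500 nM.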

Compound 3, half-maximal inhibitory concentration: 4720 nM
For compound 3 the middle estimate is 2.6-fold (0.42 log units) below the measured one; the measured number falls inside the stated range.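

In this assay chloro in place of hydrogen on this aromatic carbon, meta to a fused ring and para to a fused ring, gives a step that stays within the usual scatter (a 1.9-fold higher number from compound 1 to compound 3 (0.28 log units; within the scatter)). This first measured pair shows that a chlorine atom can sit at this position without a clear shift in the read-out. No measured evidence here bears on the reason for this result. On these data alone, whether an amine or a carboxylic acid at this same place would move the number beyond the scatter remains open.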